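From 4-fluorophenyl to 4,5-dibromothiophen-2-yl on the sulfonyl sulfur

A few compounds are considered here, and "the series" means these few. Any claim that something is new, unique, unknown or untested is made for them only; others in the source may bear on it.

In an ADME assay on Vero cells (Homo sapiens) for cytotoxicity against Vero (Chlorocebus sabaeus), read by MTT assay (a lower number here means that less compound is tolerated, a higher number that more compound is tolerated), compound 2 (`O=S(=O)(Nc1cccc2cccnc12)c1ccc(F)cc1`) stands at "not determined" (no result reported), so it offers no single number. Compound 1 (`CC(C)c1cc(C(C)C)c(S(=O)(=O)Nc2cccc3cccnc23)c(C(C)C)c1`) likewise gives "not determined" (no result reported). Among the compounds with values here, the only figure comes from compound 3 (`CCCc1ccc(S(=O)(=O)Nc2cccc3cccnc23)cc1`), at 64400 nM. Compound 4 (`O=S(=O)(Nc1cccc2cccnc12)c1cc(Br)c(Br)s1`) has not yet been measured. The change is 4,5-dibromothiophen-2-yl in place of 4-fluorophenyl on a sulfonyl sulfur. Within the data shown here, the series holds no measured step by which to size this change. With compound 3 at 64400 nM as the sole anchor, a modest step toward less compound tolerated is expected in this assay, little beyond the scatter. For compound 4 the estimated half-maximal cytotoxic concentration is 35000 nM, with an expected range of 10000 nM to 120000 nM.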

Compound 4, half-maximal cytotoxic concentration: 68700 nM
The estimate for compound 4 lay 2.0-fold (0.29 log units) below the measured number; low and high end bracket the measured number.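

Within the data shown here, compound 2 offers no single number, and no step to compound 4 can be read. Nothing measured here bears on this result. The compounds shown leave open how far 4,5-dibromothiophen-2-yl in place of 4-fluorophenyl shifts tolerance.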